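The compounds below may be only part of what the source reports. "The series", "measured", "known", "first", "only" and "open" are said of these compounds alone.

Compounds measured so far:
- compound 1, `CC(C)C(Nc1nccs1)c1ccc(-c2ccc3cccc(F)c3c2)[nH]c1=O`, 9.4 nM
- compound 2, `CC(C)C(Cc1ncc[nH]1)c1ccc(-c2ccc3cccc(F)c3c2)[nH]c1=O`, 11 nM
- compound 3, `CC(C)C(/C=C1\CCNC1=O)c1ccc(-c2ccc3cccc(F)c3c2)[nH]c1=O`, 2.2 nM

In an assay on CHO cells for displacement of a labelled ligand from prostaglandin E2 receptor EP3 subtype (Homo sapiens), read by radioligand binding (on this read-out higher numbers stand for weaker inhibition and lower numbers for stronger inhibition), compound 3 gives the lowest number of the three: the step of a 4.3-fold lower number from compound 1 to compound 3 (0.63 log units; beyond the scatter) and the step of a 5.0-fold lower number from compound 2 to compound 3 (0.70 log units; beyond the scatter) both favour compound 3. Compound 4, `CC(C)C(CC(N)=O)c1ccc(-c2ccc3cccc(F)c3c2)[nH]c1=O`, carries a different change at the same position: a group of 4 heavy atoms (2 carbon, 1 nitrogen, 1 oxygen; no ring) in place of a group of 7 heavy atoms (5 carbon, 1 nitrogen, 1 oxygen; one five-membered non-aromatic ring with 1 hetero atom), on a saturated chain carbon bound to an aromatic carbon and a saturated chain carbon. Among the measured compounds shown here, no measured step covers this exact swap, but the two steps into compound 3 show that the seven-atom ring group gave modestly lower numbers than either aromatic ring, so removing it for a smaller open-chain group is expected to give a higher number, of modest size. The expected step is a 5.5-fold higher number from compound 3 to compound 4 (0.74 log units; beyond the scatter), so compound 4 is estimated at 12 nM in this assay, within a range from 4 nM to 40 nM.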

Compound 4, inhibition constant: 5 nM
Compound 4: middle estimate off by 2.4-fold (0.38 log units), on the high side, within the range that was stated.
By their numbers in this assay, from the lowest: compound 3; then compounds 4, 1 and 2 (each within the scatter of the next, the first and the last beyond it).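

A ring is not needed at this position for a low number in this assay: the open-chain carbamoylmethyl group loses only part of the ring group's advantage (a 2.3-fold higher number from compound 3 to compound 4 (0.36 log units; beyond the scatter)) and still beats the 1H-imidazol-2-ylmethyl group (a 2.2-fold lower number from compound 2 to compound 4 (0.34 log units; beyond the scatter)). It cannot be separated from the (1,3-thiazol-2-yl)amino group (a 1.9-fold lower number from compound 1 to compound 4 (0.27 log units; within the scatter)). No evidence here explains these differences. Still open, as far as these compounds go, is whether a carboxylic acid in place of the carbamoyl group, or a longer chain ending in the same carbamoyl group, would keep the number this low.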